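Moving a Fluorine Around the Benzyl Ring

A few compounds are considered here, and "the series" means these few. Any claim that something is new, unique, unknown or untested is made for them only; others in the source may bear on it.

Measured so far:
compound 1 `O=C(/C=C/c1ccc(OCc2cn(Cc3ccccc3)nn2)cc1)c1ccc(Br)cc1`: 22%
compound 2 `O=C(/C=C/c1ccc(OCc2cn(Cc3ccccc3F)nn2)cc1)c1ccc(Br)cc1`: 29%

In a functional assay on HepG2 cells (Homo sapiens) for inhibition, read by MTT assay, with a stated time of 48 h, tested at 10 uM (on this read-out higher numbers stand for more inhibition of growth at the one concentration tested and lower numbers for less inhibition of growth), compound 1 gives 22% and compound 2 gives 29%. For the measured compounds named here, compound 2 holds the top number of the two, but the only step known, a number 7 percentage points higher from compound 1 to compound 2 (within the scatter), lies within the scatter, so the two compounds cannot be told apart on this read-out.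

Compound 3 `O=C(/C=C/c1ccc(OCc2cn(Cc3cccc(F)c3)nn2)cc1)c1ccc(Br)cc1` differs from compound 2 by 3-fluorophenyl in place of 2-fluorophenyl on a saturated chain carbon bound to an aromatic nitrogen; the same atoms are kept and only rearranged. Going by the values given here, no measured step moves a fluorine from one position to another; the single step in hand concerns adding fluorine, and it was small. The expected change in this assay is therefore none beyond the scatter, and the estimated step is a number 2 percentage points lower from compound 2 to compound 3 (within the scatter). For compound 3 the estimate in this assay is 27%, expected between 12% and 42%.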

Compound 3, percent growth inhibition at one concentration: 34%
The estimate for compound 3 lay 7 percentage points below the measured number; the range from low to high includes it.
By their numbers in this assay, from the lowest: compounds 1, 2 and 3 (each within the scatter of the next, the first and the last beyond it).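

Shifting the fluorine on the benzyl ring gives a number 5 percentage points higher from compound 2 to compound 3 (within the scatter), so in this assay 2-fluorobenzyl and 3-fluorobenzyl cannot be told apart. For the compounds shown here, the comparison with the unsubstituted benzyl group shows something new, however: placing fluoro in the 3-fluorobenzyl arrangement gives a number 12 percentage points higher from compound 1 to compound 3 (beyond the scatter), the only step here that clears the scatter, though the effect is modest. This suggests that the benzyl ring can respond to a change, while the step from the unsubstituted compound to the 2-fluorobenzyl compound remains too small to read. Nothing measured here explains the difference.

On these data alone, it remains open whether this small gain is specific to fluoro or would also appear with a larger atom such as chloro. A methoxy group or an amine on the benzyl ring could also give a different result.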